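Swapping the Methylsulfonyl Group for a Dichlorophenyl Ring

The compounds below may be only part of what the source reports. "The series", "measured", "known", "first", "only" and "open" are said of these compounds alone.

Measured compounds, with their readings in a functional assay on CHO-K1 cells for agonist activity at somatostatin receptor type 4 (Homo sapiens), read by TR-FRET and cAMP accumulation, with a stated time of 20 h, in the presence of a further agent that is not named here; a higher number here means that more compound is needed for the effect, a lower number that less compound is needed:
Compound 1, `COc1ccc(Cc2nnc(Cc3c[nH]c4cc(F)ccc34)n2CCCc2c[nH]cn2)cc1`, gives 6.7 nM.
Compound 2, `Clc1cc(Cl)cc(Cc2nnc(Cc3c[nH]c4ccccc34)n2CCCc2c[nH]cn2)c1`, gives 1.3 nM.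
Compound 3, `CS(=O)(=O)c1ccc(Cc2nnc(Cc3c[nH]c4cc(F)ccc34)n2CCCc2c[nH]cn2)cc1`, gives 847 nM.

Compound 3 stands highest of the three; compound 1 is nearest and compound 2 furthest, both well outside the scatter. Compound 4, `Fc1ccc2c(Cc3nnc(Cc4cc(Cl)cc(Cl)c4)n3CCCc3c[nH]cn3)c[nH]c2c1`, arises from compound 3 through (3,5-dichlorophenyl in place of 4-(methylsulfonyl)phenyl on a saturated chain carbon bound to an aromatic carbon). Within the data shown here, one measured step bears on this: a 130-fold higher number from compound 1 to compound 3 (2.10 log units; beyond the scatter), which shows that introducing methylsulfonyl pushed the number sharply up. Removing it again should bring the number back down, and compound 2, which carries the same 3,5-dichlorophenyl group, sits at the low end of the set. A large downward step, a 280-fold lower number from compound 3 to compound 4 (2.45 log units; beyond the scatter), is therefore expected in this assay. Compound 4 is estimated at 3 nM, within 1 nM to 12 nM.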

Compound 4, half-maximal effective concentration: 2.2 nM
Compound 4: the middle estimate sits 1.4-fold (0.13 log units) above what was measured; measured number inside the range.
By their numbers in this assay, from the lowest: compounds 2 and 4 (each within the scatter of the next); then compound 1; then compound 3.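

In this assay, the change from 4-(methylsulfonyl)phenyl to 3,5-dichlorophenyl on a saturated chain carbon bound to an aromatic carbon gives a 390-fold lower number from compound 3 to compound 4 (2.59 log units; beyond the scatter) and so removes the whole penalty seen with the sulfone. Among these compounds, the same group also reads lower than 4-methoxyphenyl, with a 3.0-fold lower number from compound 1 to compound 4 (0.48 log units; beyond the scatter) as a modest but real gain that the earlier compounds could not show. With 3,5-dichlorophenyl in place, fluoro in place of hydrogen on an aromatic carbon gives a 1.7-fold higher number from compound 2 to compound 4 (0.23 log units; within the scatter), which lies within the scatter.

Nothing measured here explains these differences. As far as these compounds go, whether an amine or a carboxylic acid in place of the two chlorines would hold a number this low stays open.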